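Para substituent swap on a benzyloxy thiazinone series

The source may report more compounds than this note shows. Statements on the series, on what has been measured and on what is new or still open speak of the compounds shown alone.

Measured compounds:
compound 1 `O=C1CSc2cc(OCc3ccccc3)ccc2N1` — 8060 nM
compound 2 `N#Cc1ccc(COc2ccc3c(c2)SCC(=O)N3)cc1` — 714 nM

In an assay on isolated protein for inhibition of Amine oxidase [flavin-containing] A (Homo sapiens), read by fluorescence and spectrophotometry, with a stated time of 20 min (a higher number here means a weaker inhibitor, a lower number a stronger inhibitor), compound 2 gives the lowest of the two numbers; the nearest is compound 1, and the step of an 11-fold lower number from compound 1 to compound 2 (1.05 log units; beyond the scatter) is the only measured one bearing on the present question. Compound 3 `O=C1CSc2cc(OCc3ccc(Br)cc3)ccc2N1` differs from compound 2 by bromo in place of cyano on an aromatic carbon. Since that earlier step came from adding cyano to the unsubstituted compound 1, exchanging cyano for bromo is expected to give back part of that gain, a modest rise in this assay, a 2.5-fold higher number from compound 2 to compound 3 (0.40 log units; beyond the scatter). Compound 3 is estimated at 1800 nM, within 500 nM to 6000 nM.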

Compound 3, half-maximal inhibitory concentration: 15600 nM
The estimate for compound 3 lay 8.7-fold (0.94 log units) below the measured number; measured number outside the range, above it.
By their numbers in this assay, from the lowest: compound 2; then compounds 1 and 3 (each within the scatter of the next).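

In this assay, bromo in place of cyano (a 22-fold higher number from compound 2 to compound 3 (1.34 log units; beyond the scatter)) removes the gain seen with cyano, while bromo in place of hydrogen (a 1.9-fold higher number from compound 1 to compound 3 (0.29 log units; within the scatter)) stays within the scatter. Of the two groups shown at this position, only cyano therefore separates from hydrogen, so the gain does not extend to every group placed there. Nothing available explains this difference.

Still open, as far as these compounds go, is how other groups at this carbon would behave, such as an amine, a carboxylic acid or a methoxy group. Also open, from the compounds shown here alone, is whether cyano would give a similar step on another carbon of that ring.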